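Compound 3 to compound 4: an untested aryl change

This account rests on a few compounds, and the source may have more. Where it says the series, first, only, none or still open, it means among the compounds named here.

Measured so far in a functional assay on K562 cells (Homo sapiens) for inhibition, read by MTT assay, with a stated time of 48 h; a higher number here means a weaker inhibitor, a lower number a stronger inhibitor 
Compound 1 `Nc1n[nH]c2cc(-c3cn([C@@H]4CN[C@H](C(=O)Nc5ccc(Cl)cc5Cl)C4)nn3)ccc12` gives 28400 nM
Compound 2 `CC(=O)Nc1n[nH]c2cc(-c3cn([C@@H]4CN[C@H](C(=O)Nc5ccc(Cl)cc5Cl)C4)nn3)ccc12` gives 2090 nM
Compound 3 `O=C(Nc1n[nH]c2cc(-c3cn([C@@H]4CN[C@H](C(=O)Nc5ccc(Cl)cc5Cl)C4)nn3)ccc12)C1CC1` gives 5340 nM

Compound 3 stands second highest of the three numbers. Its nearest neighbour is reached by a 2.6-fold higher number from compound 2 to compound 3 (0.41 log units; beyond the scatter) and its furthest by a 5.3-fold lower number from compound 1 to compound 3 (0.73 log units; beyond the scatter) on the same scale.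

Compound 4 `O=C(Nc1n[nH]c2cc(-c3cn([C@@H]4CN[C@H](C(=O)Nc5ccc(Br)cc5)C4)nn3)ccc12)C1CC1` keeps the shared core and the cyclopropylcarbonyl group of compound 3. It carries 4-bromophenyl in place of 2,4-dichlorophenyl on an amide-type nitrogen, counted as 4-bromophenyl in place of 2,4-dichlorophenyl on an amide-type nitrogen in full.

Within the data shown here, none of the measured steps covers this change. All three, including a 14-fold lower number from compound 1 to compound 2 (1.13 log units; beyond the scatter) as the largest, alter the group on a nitrogen on an aromatic ring, while the amide-type nitrogen keeps 2,4-dichlorophenyl throughout. They therefore give neither a size nor a direction for the new step, and they serve only as a rough guide to how far values can move in this series.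

With no measured basis for a shift, no step beyond the scatter is expected in this assay for now. The expected change is a 1.1-fold higher number from compound 3 to compound 4 (0.05 log units; within the scatter) as estimated here. For compound 4 the estimated value is 6000 nM with an expected range from 2500 nM to 15000 nM on this reading.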

Compound 4, half-maximal inhibitory concentration: 8080 nM
Beside the measured number, compound 4's estimate is 1.3-fold (0.13 log units) below it; the range from low to high includes it.
By their numbers in this assay, from the lowest: compound 2; then compounds 3 and 4 (each within the scatter of the next); then compound 1.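

Among these compounds, compound 4 gives the first read on the aryl group on the amide-type nitrogen, since the earlier steps all altered the group on a nitrogen on an aromatic ring: in this assay, with the cyclopropylcarbonyl group held constant, the exchange of 2,4-dichlorophenyl for 4-bromophenyl gives a 1.5-fold higher number from compound 3 to compound 4 (0.18 log units; within the scatter). Among the compounds shown here, this exchange of two chlorine atoms for one bromine atom therefore leaves the two compounds indistinguishable in this assay, so this position does not require the 2,4-dichlorophenyl group for a value in this range, though the single step cannot separate the contribution of each halogen. Nothing available explains this result.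

On these data alone, it remains open whether a plain phenyl, a 4-chlorophenyl, or a phenyl carrying an amine or a carboxylic acid on the amide-type nitrogen would also stay within the scatter of compound 3 in this assay. As far as these compounds go, it is equally open whether 4-bromophenyl would behave the same way with the acetyl group of compound 2, or with the free amino group of compound 1, in place of cyclopropylcarbonyl.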